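The source may report more compounds than this note shows. Statements on the series, on what has been measured and on what is new or still open speak of the compounds shown alone.

Compound 1 `CCc1ccc(-c2nc3ccccn3c2Sc2ccccc2)cc1`: > 100000 nM (a limit)
Compound 2 `Cc1ccc2nc(-c3ccc(Cl)cc3)c(Sc3ccccc3)n2c1`: > 100000 nM (a limit)
Compound 3 `Clc1ccc(Sc2c(-c3ccccc3)nc3ccccn23)cc1`: 91400 nM

In an ADME assay on HEK293 cells (Homo sapiens) for inhibition, read by MTT assay, with a stated time of 48 h (on this read-out lower numbers stand for stronger inhibition and higher numbers for weaker inhibition), compound 1 gives > 100000 nM, which is a limit of the assay and not a number. This is the limit of > 100000 nM in this assay, at which 2 of the 3 values shown sit. Compound 2 is reported with the same kind of limit. Only compound 3 has a measured number, 91400 nM.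

Compound 4 `c1ccc(Sc2c(-c3ccsc3)nc3ccccn23)cc1` keeps the core of compound 1 and its phenylsulfanyl group, but carries thiophen-3-yl in place of 4-ethylphenyl on an aromatic carbon. Among the measured compounds shown here, no step between measured compounds is available as a guide, so any forecast is loose. Inhibition is expected to stay weak, as compound 3 at 91400 nM is the only guide with a number. The expected change is small, either slightly towards stronger inhibition or none beyond the scatter, and the estimated step is an at least 1.1-fold lower number from compound 1 to compound 4 (0.04 log units; that floor lies within the scatter). In this assay the estimate for compound 4 is 90000 nM, with an expected range from 40000 nM to 150000 nM.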

Compound 4, half-maximal inhibitory concentration: 91700 nM
Compound 4: the middle estimate sits 1.0-fold (0.01 log units) below what was measured, within the range that was stated.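

Among the compounds shown here, replacing 4-ethylphenyl with thiophen-3-yl on this aromatic carbon, next to the ring atom that bears a phenylsulfanyl group, gives the first readable step at this position in this assay: an at least 1.0-fold lower number from compound 1 to compound 4 (0.03 log units; that floor lies within the scatter). This step is only a floor within the scatter, so it shows no gain in inhibition from the change. The smaller five-membered aromatic ring with its sulfur leaves inhibition weak at this position, and the series stays close to the assay's limit: the limit of > 100000 nM in this assay, at which 2 of the 4 values shown sit.

As far as these compounds go, the true size of the step remains open, since the value of compound 1 is a limit and not a number. From the compounds shown here alone, it is also open whether an amine, a carboxylic acid or a longer chain on this aromatic carbon would give clearly stronger inhibition.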